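The source may hold more compounds than are shown below. What is called first, only, known or untested is meant among the compounds shown, and "the series" means these compounds.

In an ADME assay on CEM-SS cells (Homo sapiens) for cytotoxicity, read by XTT assay, with a stated time of 6 days (a lower number here means that less compound is tolerated, a higher number that more compound is tolerated), compound 1 (`CCCC(=O)OCSc1ccccc1C(=O)NCC(N)=O`) gives > 100 uM, which is a limit and not a number. Compound 2 (`CCCC(=O)OCSc1ccccc1C(=O)NCC(=O)NC`) gives > 100 uM, which is also a limit. Among the measured compounds shown here, compound 3 (`CCCC(=O)OCSc1ccccc1C(=O)NC`) gives 5.7 uM, the only true number so far.

Compound 4 (`CCCC(=O)OCSc1ccccc1C(=O)NCC(=O)NCCN(C)C`) differs from compound 3 by one change: (2-(dimethylamino)ethyl)carbamoyl in place of hydrogen on a saturated chain carbon bound to an amide-type nitrogen.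

For the measured compounds named here, two measured steps concern this same place on the chain. Removing carbamoyl gives an at least 17-fold lower number from compound 1 to compound 3 (1.24 log units; beyond the scatter). Removing methylcarbamoyl gives an at least 17-fold lower number from compound 2 to compound 3 (1.24 log units; beyond the scatter). Both steps are large. The remaining step, a step that the two limits leave unreadable from compound 1 to compound 2, gives no size to work with.

Read in reverse, the steps of an at least 17-fold lower number from compound 1 to compound 3 (1.24 log units; beyond the scatter) and an at least 17-fold lower number from compound 2 to compound 3 (1.24 log units; beyond the scatter) lead to the expectation of a large move to a higher number in this assay for compound 4. Going by the values given here, the dimethylamino end of the new group has no measured precedent, so the size remains uncertain.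

The expected change is a 12-fold higher number from compound 3 to compound 4 (1.09 log units; beyond the scatter).

For compound 4 the estimated value is 70 uM, with an expected range of 20 uM to 150 uM.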

Compound 4, half-maximal toxic concentration: 76.9 uM
Compound 4: middle estimate off by 1.1-fold (0.04 log units), on the low side; low and high end bracket the measured number.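

In this assay the (2-(dimethylamino)ethyl)carbamoyl group gives a 13-fold higher number from compound 3 to compound 4 (1.13 log units; beyond the scatter), so the rise on a saturated chain carbon bound to an amide-type nitrogen now has a readable size ending in a true number, and not only a limit. Against the two compounds that sit at a limit, the steps are an at least 1.3-fold lower number from compound 2 to compound 4 (0.11 log units; that floor lies within the scatter) and an at least 1.3-fold lower number from compound 1 to compound 4 (0.11 log units; that floor lies within the scatter); both are floors within the scatter, so the new group cannot be ranked against carbamoyl or methylcarbamoyl. The comparison stays capped at the top: the limit of > 100 uM in this assay, at which 2 of the 4 values shown sit.

Whether the carbamoyl alone carries the rise, or the dimethylamino end also moves the number, remains unresolved. Also open, from the compounds shown here alone, is how a morpholine, a carboxylic acid or a longer chain in place of the dimethylamino end would read in this assay.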